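The compounds below may be only part of what the source reports. "The series", "measured", "known", "first", "only" and "open" are said of these compounds alone.

In a functional assay on A549 cells (Homo sapiens) for cytotoxicity, read by MTT assay, with a stated time of 68 h (a higher number here means a weaker inhibitor, a lower number a stronger inhibitor), compound 1 `O=C(Nc1cccc(-c2ccsc2)c1)C(Cl)Cl` gives > 50000 nM, which is a limit of the assay and not a number. Compound 2 `O=C(Nc1cccc(-c2nccs2)c1)C(Cl)Cl` gives > 50000 nM, which is likewise a limit, so its position is known only as a limit and no exact potency can be read for it. Among the measured compounds shown here, the one measured step is a step that the two limits leave unreadable from compound 1 to compound 2, and it has no readable size. The evidence therefore comes down to the limit of > 50000 nM in this assay, at which 2 of the 2 values shown sit. Compound 3 `O=C(Nc1cccc(-c2ccoc2)c1)C(Cl)Cl` differs from compound 2 by furan-3-yl in place of 1,3-thiazol-2-yl on an aromatic carbon. This puts furan-3-yl in place of 1,3-thiazol-2-yl on an aromatic carbon of a six-membered aromatic ring of carbon only, so one five-membered aromatic ring replaces another. For the measured compounds named here, the one measured exchange of this kind gives no size to carry over, and both compounds behind it stop at the limit. No step beyond the scatter is therefore expected in this assay, and no direction is favoured. The expected step is a step that the limit leaves unreadable from compound 2 to compound 3. For compound 3 the estimate is 55000 nM, with an expected range from 20000 nM to 120000 nM, and the assay may well report only a limit again.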

Compound 3, half-maximal inhibitory concentration: 8480 nM
For compound 3 the middle estimate is 6.5-fold (0.81 log units) above the measured one; the whole stated range lies above it.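

At this position, on an aromatic carbon of the six-membered ring, the choice of five-membered aromatic ring clearly matters in this assay: furan-3-yl in place of 1,3-thiazol-2-yl gives an at least 5.8-fold lower number from compound 2 to compound 3 (0.77 log units; beyond the scatter), and furan-3-yl in place of thiophen-3-yl gives an at least 5.8-fold lower number from compound 1 to compound 3 (0.77 log units; beyond the scatter). The earlier pair could not show this, since the step between compound 1 and compound 2 cannot be read, and the two new steps are known only from one side. Although 1,3-thiazol-2-yl and furan-3-yl have the same count of heavy atoms, of these three groups only furan-3-yl brings the compound off the limit, so the whole comparison rests on a single measured number set against limits: the limit of > 50000 nM in this assay, at which 2 of the 3 values shown sit.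

The compounds shown leave open whether the gain in this assay belongs to the furan ring as such or to its point of attachment, which furan-2-yl at the same place would test. They also leave open how a six-membered ring such as pyridine, or an amine or a carboxylic acid on the furan ring, would fare at this position.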